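Sulfonyl series: 4-carboxyphenyl in place of thiophen-2-yl

The source may hold more compounds than are shown below. What is called first, only, known or untested is meant among the compounds shown, and "the series" means these compounds.

In a functional assay for inhibition, with Homo sapiens as the target (a higher number here means a weaker inhibitor, a lower number a stronger inhibitor), compound 1 `CS(=O)(=O)N[C@@H](CNC(=O)c1ccc2c(c1)C(=O)N(CCC1CCNCC1)C2)C(=O)O` gives 14 nM and compound 2 `CCOCCS(=O)(=O)N[C@@H](CNC(=O)c1ccc2c(c1)C(=O)N(CCC1CCNCC1)C2)C(=O)O` gives 8 nM while compound 3 `O=C(NC[C@H](NS(=O)(=O)c1cccs1)C(=O)O)c1ccc2c(c1)C(=O)N(CCC1CCNCC1)C2` gives 7 nM on the same read-out. Compound 3 stands within the scatter of both others, with a 2.0-fold lower number from compound 1 to compound 3 (0.30 log units; within the scatter) and a 1.1-fold lower number from compound 2 to compound 3 (0.06 log units; within the scatter) as its steps. The third measured step, a 1.8-fold lower number from compound 1 to compound 2 (0.24 log units; within the scatter), also stays inside the scatter. Compound 4 `O=C(O)c1ccc(S(=O)(=O)N[C@@H](CNC(=O)c2ccc3c(c2)C(=O)N(CCC2CCNCC2)C3)C(=O)O)cc1` carries 4-carboxyphenyl in place of thiophen-2-yl on a sulfonyl sulfur with 4-carboxyphenyl in place of thiophen-2-yl on a sulfonyl sulfur. Among the measured compounds shown here, no measured compound carries this group, so the range stays wide. No step beyond the scatter is expected in this assay in either direction. The estimated step is a 1.3-fold higher number from compound 3 to compound 4 (0.11 log units; within the scatter) and remains inside the scatter. For compound 4 the expected value is 9 nM with an estimated range of 4 nM to 22 nM as the working figure.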

Compound 4, half-maximal inhibitory concentration: 7 nM
Compound 4: middle estimate off by 1.3-fold (0.11 log units), on the high side; the range from low to high includes it.
By their numbers in this assay, from the lowest: compounds 3, 4, 2 and 1 (each within the scatter of the next).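

In this assay the sulfonyl sulfur accepts 4-carboxyphenyl, which brings a hydrogen-bond donor that thiophen-2-yl lacks, with a step inside the scatter (no change at the digits printed from compound 3 to compound 4 (within the scatter)). The same holds against 2-ethoxyethyl (a 1.1-fold lower number from compound 2 to compound 4 (0.06 log units; within the scatter)) and methyl (a 2.0-fold lower number from compound 1 to compound 4 (0.30 log units; within the scatter)), so a carboxylic acid on the aromatic ring joins the other sulfonyl substituents without a step beyond the scatter. No supporting evidence bears on this result. From the compounds shown here alone, whether 4-aminophenyl, or a chain longer than 2-ethoxyethyl, on this sulfur would give a step beyond the scatter stays open.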